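Nitrophenyl ethers of methylpyrrolidine: phenyl to hydroxyphenyl

The compounds below may be only part of what the source reports. "The series", "measured", "known", "first", "only" and "open" are said of these compounds alone.

Measured so far:
compound 1 `CN1CCC[C@H]1COc1cc(C#CCCCCO)cc([N+](=O)[O-])c1`, 14.2 nM
compound 2 `CN1CCC[C@H]1COc1cc(-c2ccccc2)cc([N+](=O)[O-])c1`, 330 nM

Among the measured compounds shown here, in an assay on membranes from Cerebral cortex for displacement of a labelled ligand from Neuronal acetylcholine receptor; alpha4/beta2 (Rattus norvegicus), with a stated time of 30 min (a higher number here means a weaker inhibitor, a lower number a stronger inhibitor), compound 2 gives the higher of the two numbers; the only measured step, a 23-fold higher number from compound 1 to compound 2 (1.37 log units; beyond the scatter), replaced a 6-hydroxyhex-1-yn-1-yl group with phenyl. Compound 3 `CN1CCC[C@H]1COc1cc(-c2ccc(O)cc2)cc([N+](=O)[O-])c1` differs from compound 2 by hydroxy in place of hydrogen on an aromatic carbon. For the measured compounds named here, no measured step tests a hydroxy placed on the phenyl ring itself, so the expectation is uncertain. A hydroxy group was present in compound 1, which gave 14.2 nM, but at a different place. For compound 3 a modest downward step, a 1.7-fold lower number from compound 2 to compound 3 (0.22 log units; within the scatter), is expected in this assay. Compound 3 is estimated at 200 nM, within 60 nM to 700 nM.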

Compound 3, inhibition constant: 12 nM
Compound 3: middle estimate off by 17-fold (1.22 log units), on the high side, and the stated range ends above it.
By their numbers in this assay, from the lowest: compounds 3 and 1 (each within the scatter of the next); then compound 2.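

In this assay, a single hydroxy on the phenyl ring, para to a large group, has a large effect: a 28-fold lower number from compound 2 to compound 3 (1.44 log units; beyond the scatter). With that hydroxy in place, the gap to the open chain closes, with a 1.2-fold lower number from compound 1 to compound 3 (0.07 log units; within the scatter), so the 4-hydroxyphenyl and 6-hydroxyhex-1-yn-1-yl groups cannot be told apart in this assay. Nothing available explains why one added hydroxy matters so much. The compounds shown leave open how a methoxy or an amine at the same place would compare, and whether the hydroxy would have the same effect elsewhere on the ring.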